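Isopropoxy replaces the aryl group at the fused ring nitrogen's neighbour

This account rests on a few compounds, and the source may have more. Where it says the series, first, only, none or still open, it means among the compounds named here.

Measured compounds:
compound 1, `CC(C)(C)n1cc2c(n1)C(=O)CC1(CCN(C(=O)c3cc(-c4ccc(F)cc4)nc4ccccc34)CC1)O2`, 2930 nM
compound 2, `CN(C)c1ccc(-c2cc(C(=O)N3CCC4(CC3)CC(=O)c3nn(C(C)(C)C)cc3O4)c3ccccc3n2)cc1`, 1730 nM

Compound 2 and compound 1 share a core and differ only in the group on the pendant aromatic ring. In a functional assay on HepG2 cells (Homo sapiens) for inhibition, read by MTT assay, with a stated time of 72 h (a lower number here means a stronger inhibitor, a higher number a weaker inhibitor), compound 2 gives the lower of the two numbers, but the step of a 1.7-fold lower number from compound 1 to compound 2 (0.23 log units; within the scatter) is within the scatter, so the two compounds cannot be ordered. Compound 3, `CC(C)Oc1cc(C(=O)N2CCC3(CC2)CC(=O)c2nn(C(C)(C)C)cc2O3)c2ccccc2n1`, is not yet measured. It differs from compound 2 as follows: isopropoxy in place of 4-(dimethylamino)phenyl on an aromatic carbon. For the measured compounds named here, the only measured step, from fluoro to dimethylamino on that aryl ring, changes a substituent on the group that is now removed altogether, so it does not speak directly to this change. Going by the values given here, with no measured step bearing on the loss of the whole aryl group, compound 3 is expected to give 4000 nM, between 1200 nM and 15000 nM, a step of a 2.3-fold higher number from compound 2 to compound 3 (0.36 log units; beyond the scatter) that is an estimate resting on no direct precedent.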

Compound 3, half-maximal inhibitory concentration: 3150 nM
The estimate for compound 3 lay 1.3-fold (0.10 log units) above the measured number; measured number inside the range.
By their numbers in this assay, from the lowest: compounds 2, 1 and 3 (each within the scatter of the next).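

In this assay, the position next to the ring nitrogen accepts isopropoxy in place of an entire aryl group without a readable difference: the exchange for 4-(dimethylamino)phenyl gives a 1.8-fold higher number from compound 2 to compound 3 (0.26 log units; within the scatter) and the exchange for 4-fluorophenyl gives a 1.1-fold higher number from compound 1 to compound 3 (0.03 log units; within the scatter) in this assay. The earlier pair varied only a substituent on the aryl ring, whereas compound 3 shows that, within this series of three, a six-membered aromatic ring of carbon only is not needed at this position for a number within the scatter of the other two. No measurement is available that explains this result.

As far as these compounds go, it remains open whether an amine, a carboxylic acid or a longer alkoxy chain at this position would give a number within the same scatter. From the compounds shown here alone, all three compounds also carry the same shared core, so how the exchange behaves on any other core is unknown.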